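The compounds below may be only part of what the source reports. "The series", "measured", "known", "first", "only" and "open" are said of these compounds alone.

Working notes on the acetoxy series in a functional assay on CHO cells for antagonist activity at adenosine receptor A2b (Homo sapiens), read by cAMP accumulation; on this read-out lower numbers stand for stronger inhibition and higher numbers for weaker inhibition. Compound 1 `CC(=O)Oc1ccc(-c2cc3ccc(OC(C)=O)c(OC(C)=O)c3oc2=O)cc1` gives > 30000 nM, which is a limit of the measurement rather than a number. Compound 2 `CC(=O)Oc1ccc(-c2cc3cccc(OC(C)=O)c3oc2=O)cc1OC(C)=O` likewise gives only a limit, > 30000 nM. Both values therefore sit at the limit of > 30000 nM in this assay, at which 2 of the 2 values shown sit. Compound 3 `CC(=O)Oc1ccc(-c2cc3ccc(OC(C)=O)c(OC(C)=O)c3oc2=O)cc1OC(C)=O` is not yet measured; it differs from compound 2 by acetoxy in place of hydrogen on an aromatic carbon. For the measured compounds named here, no step between measured compounds is available, so no size of effect can be read from the data. The step that the limit leaves unreadable from compound 2 to compound 3 is expected to stay within the scatter, with another limit the most likely outcome. For compound 3 the estimate is 40000 nM, within 10000 nM to 100000 nM.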

Compound 3, half-maximal inhibitory concentration: > 30000 nM
Compound 3 was reported as a limit (the forecaster's own chance of this, stated with the estimate: 80%); the middle value lies beyond the limit too.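

Compound 3 also reads only as a limit, so no size can be read for the steps to it from compound 1 or compound 2: the limit of > 30000 nM in this assay, at which 3 of the 3 values shown sit. The compounds shown leave open what effect an added acetoxy group has on inhibition.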